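Compound 4: a new group on a thiocarbonyl carbon

The source may report more compounds than this note shows. Statements on the series, on what has been measured and on what is new or still open speak of the compounds shown alone.

Measured so far in a functional assay on HCT-116 cells (Homo sapiens) for inhibition, read by CCK-8 assay, with a stated time of 48 h; a higher number here means a weaker inhibitor, a lower number a stronger inhibitor
Compound 1 `COc1ccc(CN(C(=O)CSc2nc3ccccc3o2)c2cc(OC)c(OC)c(OC)c2)cc1` gives 3280 nM
Compound 2 `COc1ccc(CN(C(=O)CSC(=S)N2CCCC2)c2cc(OC)c(OC)c(OC)c2)cc1` gives 4970 nM
Compound 3 `COc1ccc(CN(C(=O)CSC(=S)N2CCc3ccccc32)c2cc(OC)c(OC)c(OC)c2)cc1` gives 7710 nM

Compound 3 holds the highest of these three numbers, yet only part of that gap counts. The data show a 2.4-fold higher number from compound 1 to compound 3 (0.37 log units; beyond the scatter) but also a 1.6-fold higher number from compound 2 to compound 3 (0.19 log units; within the scatter) and so leave compound 2 and compound 3 unresolved.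

Compound 4 `COc1ccc(CN(C(=O)CSC(=S)N2CCCc3cc(OC)ccc32)c2cc(OC)c(OC)c(OC)c2)cc1` carries 6-methoxy-1,2,3,4-tetrahydroquinolin-1-yl in place of 2,3-dihydro-1H-indol-1-yl on a thiocarbonyl carbon, a change counted as 6-methoxy-1,2,3,4-tetrahydroquinolin-1-yl in place of 2,3-dihydro-1H-indol-1-yl on a thiocarbonyl carbon in full.

Going by the values given here, the closest precedent is the exchange at this same place, which gave a 1.6-fold higher number from compound 2 to compound 3 (0.19 log units; within the scatter) and stayed small. The wider exchange on the sulfur gave a 1.5-fold higher number from compound 1 to compound 2 (0.18 log units; within the scatter) and was small as well. Among the compounds with values here, no measured compound contains the entering group, so the direction remains open. The expectation is therefore no step beyond the scatter, with an estimated 1.2-fold lower number from compound 3 to compound 4 (0.07 log units; within the scatter) in this assay as the working figure.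

The expected value for compound 4 is 6500 nM (estimated range 2400 nM to 16000 nM).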

Compound 4, half-maximal inhibitory concentration: > 20000 nM
Compound 4 ended at the assay's limit (the forecaster's own chance of this, stated with the estimate: 5%); middle value at least 3.0-fold (0.48 log units) away from the limit.
By their numbers in this assay, from the lowest: compounds 1, 2 and 3 (each within the scatter of the next, the first and the last beyond it). At a limit, above all of these: compound 4.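

The exchange on a thiocarbonyl carbon, which had stayed within the scatter between pyrrolidin-1-yl and 2,3-dihydro-1H-indol-1-yl, now gives steps beyond it in this assay, with an at least 2.5-fold higher number from compound 3 to compound 4 (0.41 log units; beyond the scatter) and an at least 4.0-fold higher number from compound 2 to compound 4 (0.60 log units; beyond the scatter). The value of compound 4 is a limit and not a number, so both steps give only a minimum size: the limit of > 20000 nM in this assay, at which 1 of the 4 values shown sits. This place is therefore not indifferent to the group it carries, as this one entering group shows.

The change brings a six-membered non-aromatic ring and a methoxy group in a single step, and the compounds shown do not tell which of the two accounts for it. As far as these compounds go, whether 1,2,3,4-tetrahydroquinolin-1-yl without the methoxy, piperidin-1-yl or morpholin-4-yl would stay in the range of compound 2 and compound 3 remains open.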